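Three Amines on One Core: Isopropyl to Cyclohexyl

The source may hold more compounds than are shown below. What is called first, only, known or untested is meant among the compounds shown, and "the series" means these compounds.

Measured so far:
compound 1 `CCNCCCOc1ccc2cc(NC(=O)c3ccc(O)c(CC=C(C)C)c3)c(=O)oc2c1C` gives 720 nM
compound 2 `CCN(C)CCCOc1ccc2cc(NC(=O)c3ccc(O)c(CC=C(C)C)c3)c(=O)oc2c1C` gives 730 nM
compound 3 `CC(C)=CCc1cc(C(=O)Nc2cc3ccc(OCCCNC(C)C)c(C)c3oc2=O)ccc1O` gives 750 nM

In a functional assay on SK-BR-3 cells (Homo sapiens) for antiproliferative activity (a lower number here means a stronger inhibitor, a higher number a weaker inhibitor), compound 3 stands with the highest of the three numbers, yet its steps of a 1.0-fold higher number from compound 1 to compound 3 (0.02 log units; within the scatter) and a 1.0-fold higher number from compound 2 to compound 3 (0.01 log units; within the scatter) both lie within the scatter, so the three compounds cannot be told apart. Compound 4 `CC(C)=CCc1cc(C(=O)Nc2cc3ccc(OCCCNC4CCCCC4)c(C)c3oc2=O)ccc1O` carries cyclohexyl in place of isopropyl on an amine nitrogen. Among the measured compounds shown here, the steps that bear on this are those that also alter the amine substituent: a 1.0-fold higher number from compound 1 to compound 2 (0.01 log units; within the scatter), a 1.0-fold higher number from compound 1 to compound 3 (0.02 log units; within the scatter) and a 1.0-fold higher number from compound 2 to compound 3 (0.01 log units; within the scatter), none of which moved the number beyond the scatter. The cyclohexyl group is larger than any group tried so far, so this expectation rests on fewer comparable examples, but on the evidence shown no step beyond the scatter is expected in this assay. Compound 4 is therefore estimated at 750 nM, within a range of 350 nM to 1600 nM, which means an expected step of no change at the digits printed from compound 3 to compound 4 (within the scatter).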

Compound 4, half-maximal inhibitory concentration: 660 nM
Compound 4: middle estimate off by 1.1-fold (0.06 log units), on the high side; the measured number falls inside the stated range.
By their numbers in this assay, from the lowest: compounds 4, 1, 2 and 3 (each within the scatter of the next).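

In this assay the cyclohexyl ring, with six carbons against the three of isopropyl, leaves the number within the scatter of all three earlier compounds (a 1.1-fold lower number from compound 3 to compound 4 (0.06 log units; within the scatter)), (a 1.1-fold lower number from compound 2 to compound 4 (0.04 log units; within the scatter)) and (a 1.1-fold lower number from compound 1 to compound 4 (0.04 log units; within the scatter)). Among the compounds shown, this amine nitrogen therefore accepts a six-membered carbon ring as well as it accepts short open chains. Nothing measured here says why.

The compounds shown leave open whether a phenyl group or a piperazine ring on this nitrogen would hold the number in the same way, and whether an amide in place of the amine would.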